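The source may hold more compounds than are shown below. What is called first, only, known or untested is meant among the compounds shown, and "the series" means these compounds.

In a functional assay on T47D cells (Homo sapiens) for cytotoxicity, read by CCK-8 assay and cell counting, with a stated time of 2 days (a higher number here means a weaker inhibitor, a lower number a stronger inhibitor), compound 1 `Oc1ccc(-c2cc(-c3cccnc3)nc(-c3ccccc3Cl)c2)cc1` stands as "not determined" (no result reported). Among the measured compounds shown here, compound 2 `Oc1cccc(-c2cc(-c3ccsc3)nc(-c3ccccc3Cl)c2)c1` is therefore the only compound with a number to stand on: in this assay compound 2 gives 2440 nM, the sole reference point in this set. Compound 3 `Oc1ccc(-c2cc(-c3ccsc3)nc(-c3ccccc3Cl)c2)cc1` is yet to be measured and differs from compound 2 by 4-hydroxyphenyl in place of 3-hydroxyphenyl on an aromatic carbon. For the measured compounds named here, no measured pair in the set shows a change of this kind, so nothing in the data sets its size. The expected step of a 1.0-fold higher number from compound 2 to compound 3 (0.01 log units; within the scatter) is none beyond the usual scatter, in either direction. For compound 3 in this assay the estimate is 2500 nM, within a range from 900 nM to 7000 nM.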

Compound 3, half-maximal inhibitory concentration: 6110 nM
For compound 3 the middle estimate is 2.4-fold (0.39 log units) below the measured one, and the stated range covers the measured number.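

In this assay the change of 3-hydroxyphenyl to 4-hydroxyphenyl gives a 2.5-fold higher number from compound 2 to compound 3 (0.40 log units; beyond the scatter) at this position, opposite the ring nitrogen. The two groups hold the same atoms, so this position responds to where the hydroxyl stands on the phenyl ring, and the 3-hydroxyphenyl compound is the stronger of this pair. Nothing available explains the difference. As far as these compounds go, whether a methoxy group or an amine in place of the hydroxyl would hold or lose activity stays open. So does the outcome of a 2-hydroxyphenyl group here.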